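From methylsulfanyl to benzylsulfanyl on the shared core

The source may report more compounds than this note shows. Statements on the series, on what has been measured and on what is new or still open speak of the compounds shown alone.

In a functional assay on HCT-116 cells (Homo sapiens) for inhibition, read by MTT assay, with a stated time of 48 h (a higher number here means a weaker inhibitor, a lower number a stronger inhibitor), compound 1 `COc1ccc(-n2c(SCc3ccccc3)nnc2-c2cc(OC)c(OC)c(OC)c2)cc1` gives a measured number, 42400 nM. Compound 2 `COc1cc(-c2nnc(S)n2-c2ccc(N(C)C)cc2)cc(OC)c1OC` is reported only as a limit, > 60000 nM. Compound 3 `COc1cc(-c2nnc(SC)n2-c2ccc(N(C)C)cc2)cc(OC)c1OC` is also reported only as a limit, > 60000 nM. Compound 3 therefore has no exact position on the scale, and a limit cannot be treated as a number. Among the compounds with values here, the one measured step that bears on this change is a step that the two limits leave unreadable from compound 2 to compound 3, so it offers no size to carry forward.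

Compound 4 `COc1cc(-c2nnc(SCc3ccccc3)n2-c2ccc(N(C)C)cc2)cc(OC)c1OC` keeps the core of compound 3 and differs in one place: phenyl in place of hydrogen on a saturated chain carbon bound to a sulfur. Put simply, methylsulfanyl becomes benzylsulfanyl. Within the data shown here, compound 1 carries the same benzylsulfanyl group and gives 42400 nM, which makes it the only numerical guide, although the rest of its structure is not identical. A modest move towards stronger inhibition in this assay is therefore expected, but with little confidence. The expected change is an at least 1.5-fold lower number from compound 3 to compound 4 (0.17 log units; that floor lies within the scatter), an estimate that starts from a limit rather than a number. Compound 4 is estimated at 40000 nM, with an expected range from 15000 nM to 60000 nM.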

Compound 4, half-maximal inhibitory concentration: 54000 nM
Compound 4: middle estimate off by 1.4-fold (0.13 log units), on the low side; low and high end bracket the measured number.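

Compound 4 is the only compound shown with dimethylamino on the aryl ring that gives a measured number in this assay, so a phenyl on the saturated chain carbon bound to the sulfur still leaves the reading on the scale, yet the steps that can be drawn are small: an at least 1.1-fold lower number from compound 3 to compound 4 (0.04 log units; that floor lies within the scatter), and an at least 1.1-fold lower number from compound 2 to compound 4 (0.04 log units; that floor lies within the scatter). Both are floors within the scatter, and their true sizes cannot be read, as compound 2 and compound 3 are each reported only as a limit and not as a number: the limit of > 60000 nM in this assay, at which 2 of the 4 values shown sit. With benzylsulfanyl held fixed, the swap of methoxy for dimethylamino gives a 1.3-fold higher number from compound 1 to compound 4 (0.11 log units; within the scatter), which is also within the scatter, so this swap does not tell compound 1 and compound 4 apart.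

Still open, on these data alone, is whether any group on this sulfur can produce a step clearly beyond the scatter, and how far compound 2 and compound 3 really lie from compound 4. As far as these compounds go, the effect of a longer chain between the sulfur and the phenyl, or of an amine or a carboxylic acid on that chain, also remains unknown.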